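The compounds below may be only part of what the source reports. "The series", "measured", "known", "first", "only" and "open" are said of these compounds alone.

Compounds measured:
compound 1, `CNC(=O)c1cc(Oc2ccc(NC(=O)c3nccc(-c4ccc(OC)cc4)n3)cc2)ccn1`: 14200 nM
compound 2, `CNC(=O)c1cc(Oc2ccc(NC(=O)c3cc(-c4ccc(OC)cc4)ncn3)cc2F)ccn1`: 56200 nM
compound 3, `CNC(=O)c1cc(Oc2ccc(NC(=O)c3nccc(-c4ccc(OC)cc4)n3)cc2F)ccn1`: 24300 nM

In a functional assay on PC-3 cells (Homo sapiens) for cytotoxicity, read by MTT assay, with a stated time of 72 h (a lower number here means a stronger inhibitor, a higher number a weaker inhibitor), compound 1 gives the number quoted above, and compound 3 lies close to it, the step of a 1.7-fold higher number from compound 1 to compound 3 (0.23 log units; within the scatter) falling within the scatter. Compound 2 gives a higher number than compound 1, and that gap exceeds the scatter. Compound 4, `CNC(=O)c1cc(Oc2ccc(NC(=O)c3nccc(-c4ccc([N+](=O)[O-])cc4)n3)cc2)ccn1`, differs from compound 1 in a single respect: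

nitro in place of methoxy on an aromatic carbon

Going by the values given here, none of the measured steps involves this change; the only step with one change, from compound 1 to compound 3, concerns a fluoro substituent elsewhere and says nothing about the methoxy group. With no guidance in the data, the step of a 1.1-fold higher number from compound 1 to compound 4 (0.02 log units; within the scatter) is expected to stay within the scatter. Compound 4 is therefore estimated at 15000 nM, with a range from 5000 nM to 45000 nM.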

Compound 4, half-maximal inhibitory concentration: > 100000 nM
Compound 4 ended at the assay's limit (the forecaster's own chance of this, stated with the estimate: 15%); at least 6.6-fold (0.82 log units) between middle value and limit.
By their numbers in this assay, from the lowest: compounds 1 and 3 (each within the scatter of the next); then compound 2. At a limit, above all of these: compound 4.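

In this assay, the carbon para to a large group proves sensitive to what it carries: replacing methoxy with nitro gives an at least 7.0-fold higher number from compound 1 to compound 4 (0.84 log units; beyond the scatter). The earlier single change, fluoro in place of hydrogen, stayed within the scatter and left this carbon untouched. Compound 4 gives > 100000 nM, which is a limit of the assay and not a number, so the full size of the step remains unknown: the limit of > 100000 nM in this assay, at which 1 of the 4 values shown sits.

The compounds shown do not tell whether nitro specifically or any departure from methoxy produces this result. Going by these compounds, what an amine, a hydroxy group or plain hydrogen would give at this carbon remains open.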